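The compounds below may be only part of what the source reports. "The series", "measured", "known", "first", "only" and "open" are said of these compounds alone.

Measured compounds in an assay on CHO cells for displacement of a labelled ligand from C-X-C chemokine receptor type 1 (Homo sapiens); a lower number here means a stronger inhibitor, a higher number a weaker inhibitor:
- Compound 1 `CC[C@@H](Nc1c(Nc2cccc(C(=O)N(C)C)c2O)c(=O)c1=O)c1sccc1C`: 123 nM
- Compound 2 `CC[C@@H](Nc1c(Nc2cccc(C(=O)N(C)C)c2O)c(=O)c1=O)c1cc(C)co1`: 9 nM

Compound 2 holds the lower of the two numbers; the only other point, compound 1, sits a good deal higher, and that gap reads as a 14-fold lower number from compound 1 to compound 2 (1.14 log units; beyond the scatter), well beyond the scatter.

Compound 3 `CCc1ccoc1[C@@H](CC)Nc1c(Nc2cccc(C(=O)N(C)C)c2O)c(=O)c1=O` is the next point. It differs from compound 2 by 3-ethylfuran-2-yl in place of 4-methylfuran-2-yl on a saturated chain carbon bound to a nitrogen on an aromatic ring and a saturated chain carbon. For the measured compounds named here, no measured pair carries this exact change. Going by the values given here, the one step that bears on the same position, from compound 1 to compound 2, swapped a thiophene for a furan and was large, a 14-fold lower number from compound 1 to compound 2 (1.14 log units; beyond the scatter). The present change keeps the furan and alters only the alkyl substituent and its position on the ring, so that earlier step gives little guidance on size; the direction cannot be read from the two points at hand.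

The expectation for compound 3 in this assay is therefore a step of about a 1.7-fold higher number from compound 2 to compound 3 (0.22 log units; within the scatter) from compound 2, most likely within the scatter, with a wide band. Compound 3 is estimated at 15 nM, range 5 nM to 45 nM.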

Compound 3, inhibition constant: 379 nM
The estimate for compound 3 lay 25-fold (1.40 log units) below the measured number; measured number above the stated range.
By their numbers in this assay, from the lowest: compound 2; then compound 1; then compound 3.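

In this assay, keeping the furan does not by itself keep the number low: a 42-fold higher number from compound 2 to compound 3 (1.62 log units; beyond the scatter), so this position responds strongly even to a change from one alkyl furan to another, on a saturated chain carbon bound to a nitrogen on an aromatic ring and a saturated chain carbon. The earlier step, a 14-fold lower number from compound 1 to compound 2 (1.14 log units; beyond the scatter), could be read as favouring furan over thiophene, but a 3.1-fold higher number from compound 1 to compound 3 (0.49 log units; beyond the scatter) shows that a furan can also give a higher number than the 3-methylthiophen-2-yl compound, so the ring type alone does not set the order among these three compounds. The substitution on the ring matters at least as much as the ring itself, though nothing at hand gives a reason for the size of these steps.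

The change from 4-methylfuran-2-yl to 3-ethylfuran-2-yl alters both the alkyl group and where it sits on the furan, and these compounds cannot separate the two contributions. Also open, as far as these compounds go, is whether an unsubstituted furan-2-yl, or a propyl chain in place of the methyl of 4-methylfuran-2-yl, would hold the low number of compound 2 at 9 nM.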